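Swapping Benzoyl for Cyano on a Shared Side Chain

The source may hold more compounds than are shown below. What is called first, only, known or untested is meant among the compounds shown, and "the series" means these compounds.

Compound 1 `C=C[C@@](C)(/C=C/c1ccc(O)cc1)CC/C=C/C(=O)c1ccccc1` and compound 2 `C=C[C@@](C)(/C=C/c1ccc(O)cc1)CC/C=C/C#N` share one core and differ in a single place: cyano in place of benzoyl on a double-bonded chain carbon bound to a double-bonded chain carbon. In a functional assay on HepG2 cells (Homo sapiens) for cytotoxicity, with a stated time of 72 h (on this read-out higher numbers stand for an effect only at larger amounts of compound and lower numbers for an effect already at smaller amounts), compound 1 reaches only a limit of the assay, > 52000 nM. In this assay compound 2 likewise reaches only a limit, > 52000 nM. The size of the step that the two limits leave unreadable from compound 1 to compound 2 cannot be read because the limit of > 52000 nM in this assay, at which 3 of the 3 values shown sit, leaves both ends open.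

Compound 3 `C=C[C@@](C)(/C=C/c1ccc(O)c(/C=C/C(=O)c2ccccc2)c1)CCC=C(C)C` is built on a different core; the difference between the two cores is not broken down here. In this assay compound 3 again reaches only a limit, > 52000 nM.

Compound 4 `C=C[C@@](C)(/C=C/c1ccc(O)c(/C=C/C#N)c1)CCC=C(C)C` has not been measured. It differs from compound 3 by cyano in place of benzoyl on a double-bonded chain carbon bound to a double-bonded chain carbon, the same change that separates compound 1 from compound 2, at the same place.

For compound 4 the step from compound 3 is expected to be a step that the limit leaves unreadable from compound 3 to compound 4, set beside the earlier unreadable step, and this expectation rests on every shown value sitting at the limit of > 52000 nM in this assay, at which 3 of the 3 values shown sit, with nothing pointing elsewhere. For compound 4 the estimate in this assay is 60000 nM, most likely reported once more as a limit rather than a number.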

Compound 4, half-maximal effective concentration: > 52000 nM
Compound 4 ended at the assay's limit; the forecaster's own chance of this, stated with the estimate: 80%; the middle value does not contradict the limit.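

No step size can be read for the change from benzoyl to cyano between compound 3 and compound 4, because both results are limits of the assay rather than numbers: the limit of > 52000 nM in this assay, at which 4 of the 4 values shown sit.

The compounds shown leave open whether this change alters cytotoxicity at all, since none of them gives a value that can be read as a number in this assay.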